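Adding a (Phenoxycarbonyl)amino Group to Compound 2

The source may report more compounds than this note shows. Statements on the series, on what has been measured and on what is new or still open speak of the compounds shown alone.

Of the compounds shown here, two sharing one core have been measured in an assay on microsomes from brain for inhibition of Fatty-acid amide hydrolase 1 (Rattus norvegicus), read by fluorescence and HPLC, with a stated time of 45 min; on this read-out higher numbers stand for weaker inhibition and lower numbers for stronger inhibition. Compound 1 `N#CNC(COc1ccc(Oc2ccccc2)cc1)Cn1ncnn1` gives 5300 nM in this assay. Compound 2 `O=C(COc1ccc(Oc2ccccc2)cc1)Cn1ncc2ccccc21` gives 2600 nM in this assay, the lowest of the two numbers, and its gap to compound 1, the nearest of them, lies beyond the usual scatter.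

Compound 3 `O=C(COc1ccc(Oc2ccccc2)cc1)Cn1ncc2cc(NC(=O)Oc3ccccc3)ccc21` has not yet been measured. It differs from compound 2 by (phenoxycarbonyl)amino in place of hydrogen on an aromatic carbon. No comparable change between measured compounds is available, so any expectation rests on the value of compound 2 alone and on the size of the added group. A move toward stronger inhibition, meaning a lower number, is the expected outcome, and the step of a 13-fold lower number from compound 2 to compound 3 (1.11 log units; beyond the scatter) is estimated to fall beyond the scatter. Compound 3 is expected to give 200 nM in this assay, with a range from 20 nM to 2000 nM.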

Compound 3, half-maximal inhibitory concentration: 2100 nM
Compound 3: middle estimate off by 11-fold (1.02 log units), on the low side, and the stated range ends below it.
By their numbers in this assay, from the lowest: compounds 3 and 2 (each within the scatter of the next); then compound 1.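

In this assay the exchange of hydrogen for (phenoxycarbonyl)amino on this aromatic carbon amounts to a 1.2-fold lower number from compound 2 to compound 3 (0.09 log units; within the scatter) and so gives no readable change in the number. This shows that the position, on the six-membered aromatic ring of carbon only that belongs to the fused system, can carry this whole added group, with its own aromatic ring, while compound 3 stays within the scatter of compound 2. Nothing measured here explains why the added group leaves the number where it is.

On these data alone, whether a plain amine or a carboxylic acid on this same aromatic carbon would move the number beyond the scatter remains open. Also open, as far as these compounds go, is what (phenoxycarbonyl)amino would do on another carbon of that ring.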